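Swapping Methylamino for a Triazolyl Group on a Shared Core

The source may report more compounds than this note shows. Statements on the series, on what has been measured and on what is new or still open speak of the compounds shown alone.

Compound 1, `CNc1nc(NC)nc(NC2(C#N)CCCCC2)n1`, was tested in an in vitro assay on Sf21 cells for inhibition of high affinity 3',5'-cyclic-AMP phosphodiesterase 7A (Homo sapiens); a lower number here means a stronger inhibitor, a higher number a weaker inhibitor. In this assay compound 1 gives > 1000 nM, which is a limit of the assay rather than a measured number. A second compound, compound 2 with the structure `CNc1nc(C#N)nc(NC2(C#N)CCCCC2)n1`, carries cyano in place of methylamino on an aromatic carbon. In this assay compound 2 gives > 1000 nM, again a limit and not a number. The step that the two limits leave unreadable from compound 1 to compound 2 therefore cannot be read, because of the limit of > 1000 nM in this assay, at which 2 of the 2 values shown sit.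

Compound 3, `CNc1nc(NC2(C#N)CCCCC2)nc(-n2cncn2)n1`, has not yet been measured. It differs from compound 1 in one place: 1H-1,2,4-triazol-1-yl in place of methylamino on an aromatic carbon. Among the measured compounds shown here, no measured step changes this position in the same way, so the measured pair gives no direction for the new step. Both measured compounds sit at the limit, as the limit of > 1000 nM in this assay, at which 2 of the 2 values shown sit, shows, and a weak inhibitor is expected for compound 3 as well. The step that the limit leaves unreadable from compound 1 to compound 3 is estimated to be none beyond the scatter, though its true size is uncertain. Compound 3 is expected to give about 3000 nM in this assay, within a range from 800 nM to 20000 nM, with a real chance that only a limit is reported.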

Compound 3, half-maximal inhibitory concentration: > 5000 nM
Compound 3: a limit, no number; the forecaster's own chance of this, stated with the estimate: 70%; at least 1.6-fold (0.22 log units) between middle value and limit.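

In this assay compound 3 gives > 5000 nM as a limit of the assay and not a number. Compound 1 and compound 2 also stand at limits, so no step among these three compounds can be read. The compounds shown leave open how strongly each one inhibits, and whether methylamino, cyano or 1H-1,2,4-triazol-1-yl at this place makes any difference.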